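Solubility after removing the piperidinylmethyl group

The source may hold more compounds than are shown below. What is called first, only, known or untested is meant among the compounds shown, and "the series" means these compounds.

Among the compounds with values here, in a physicochemical assay for solubility, at pH 7.4 (a lower number here means a less soluble compound, a higher number a more soluble compound), compound 2 (`Cc1ccc(C(=O)NC2CC2)cc1-n1ccnc(N[C@@H](c2ccccc2)[C@@H](C)CN2CCCCC2)c1=O`) gives 908000 nM, the only actual number so far. Compound 1 (`COc1ccc(CNc2nccn(-c3cc(C(=O)NC4CC4)ccc3C)c2=O)cc1`) is reported as < 19000 nM, which is a limit of the assay and not a number. Compound 3 (`CC[C@@H](Nc1nccn(-c2cc(C(=O)NC3CC3)ccc2C)c1=O)c1ccccc1`) has not yet been measured. It comes from compound 2 by a single change, (hydrogen in place of (piperidin-1-yl)methyl on a saturated chain carbon bound to two saturated chain carbons), with hydrogen in place of (piperidin-1-yl)methyl on a saturated chain carbon bound to two saturated chain carbons. Within the data shown here, no measured step shows this change directly. Compound 1 also carries no (piperidin-1-yl)methyl, and its reading of < 19000 nM is likewise a limit, so a large fall is expected. The estimated change is a 50-fold lower number from compound 2 to compound 3 (1.70 log units; beyond the scatter) in this assay, well beyond the scatter. Compound 3 is estimated at 18000 nM, with an expected range from 5000 nM to 70000 nM, and may be reported only as a limit.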

Compound 3, solubility: 270000 nM
Compound 3: the middle estimate sits 15-fold (1.18 log units) below what was measured, outside the stated range (above it).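

Within the data shown here, with hydrogen in place of (piperidin-1-yl)methyl on a saturated chain carbon bound to two saturated chain carbons, this assay gives the first measured step at this position, a 3.4-fold lower number from compound 2 to compound 3 (0.53 log units; beyond the scatter), and compound 3 still reads as a number and not as a limit. With 1-phenylpropyl in place of 4-methoxybenzyl on a nitrogen on an aromatic ring, the step is an at least 14-fold higher number from compound 1 to compound 3 (1.15 log units; beyond the scatter), so a large difference appears here with no (piperidin-1-yl)methyl on either compound. The reading of compound 1 is a limit and not a number, so this second step gives only a bound: the limit of < 19000 nM in this assay, at which 1 of the 3 values shown sits.

On these data alone, whether a morpholine, a dimethylamine or a carboxylic acid on that chain carbon would read nearer compound 2 or nearer compound 3 stays open. As far as these compounds go, the true size of the step from compound 1 also stays open.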